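A few compounds are considered here, and "the series" means these few. Any claim that something is new, unique, unknown or untested is made for them only; others in the source may bear on it.

Measured in a functional assay on HGC-27 cells (Homo sapiens) for inhibition, read by MTT assay, with a stated time of 72 h; a higher number here means a weaker inhibitor, a lower number a stronger inhibitor:
- compound 1 (`Cc1cc(N2CC[C@@H](C)[C@@H](N(C)c3ncnc4[nH]ccc34)C2)n2ncnc2n1`): 11300 nM
- compound 2 (`C[C@@H]1CCN(c2cc(-c3ccccc3)nc3ncnn23)C[C@@H]1N(C)c1ncnc2[nH]ccc12`): > 100000 nM (a limit, not a number)

Compound 2 has only a limit and stands at the limit of > 100000 nM in this assay, at which 1 of the 2 values shown sits, with no number of its own. Next in the series is compound 3 (`CCc1cc(N2CC[C@@H](C)[C@@H](N(C)c3ncnc4[nH]ccc34)C2)n2ncnc2n1`), with ethyl in place of phenyl on an aromatic carbon. Among the measured compounds shown here, one measured step bears on this change. It is an at least 8.8-fold higher number from compound 1 to compound 2 (0.94 log units; beyond the scatter), beyond the scatter and bounded on one side by the limit, and it comes from phenyl in place of methyl at the same place. Compound 3 goes back from phenyl to a small alkyl group, so a move to a lower number in this assay is expected, beyond the scatter. Compound 1, the methyl member, gives 11300 nM and serves as the anchor for that expectation. For the measured compounds named here, no ethyl compound has been measured, so the range stays wide. The estimated step is an at least 6.2-fold lower number from compound 2 to compound 3 (0.79 log units; beyond the scatter). For compound 3 the expected value is 16000 nM, with an estimated range of 6000 nM to 45000 nM.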

Compound 3, half-maximal inhibitory concentration: > 100000 nM
Compound 3: only a limit was reported; the forecaster's own chance of this, stated with the estimate: 10%; middle value at least 6.2-fold (0.79 log units) away from the limit.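

In this assay, lengthening methyl to ethyl at this aromatic carbon is already enough to lose the measurable value, with a step beyond the scatter and bounded on one side by a limit: an at least 8.8-fold higher number from compound 1 to compound 3 (0.94 log units; beyond the scatter). The loss seen with phenyl therefore does not require an aromatic ring at this position, and among the three compounds only compound 1, the methyl member, gives a number, 11300 nM. The step from compound 2 to compound 3 cannot be read, because both values are limits and not numbers: the limit of > 100000 nM in this assay, at which 2 of the 3 values shown sit.

As far as these compounds go, it remains open whether hydrogen, an amine or a methoxy group at this aromatic carbon would give a lower number than compound 1 does in this assay. From the compounds shown here alone, how far compound 2 and compound 3 lie past their limits is also open, so ethyl and phenyl cannot be ranked against each other.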